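The compounds below may be only part of what the source reports. "The series", "measured", "known", "first", "only" and "open" are said of these compounds alone.

Working notes on the series. Compound 1 `CC(C)(C)NCc1c(C(=O)O)nn(-c2ccccc2)c1-c1ccc(Br)cc1` serves as the anchor; in a functional assay on U-251 cells (Homo sapiens) for inhibition, read by sulforhodamine B assay, with a stated time of 48 h (on this read-out lower numbers stand for stronger inhibition of growth and higher numbers for weaker inhibition of growth), compound 1 gives 126000 nM. Compound 2 `CC(C)(C)NCc1c(C(=O)O)nn(-c2ccccc2)c1-c1ccccc1` differs from it by hydrogen in place of bromo on an aromatic carbon. In this assay compound 2 returns only a limit of the assay, > 716000 nM. The step of an at least 5.6-fold higher number from compound 1 to compound 2 (0.75 log units; beyond the scatter) therefore rests on (the limit of > 716000 nM in this assay, at which 1 of the 3 values shown sits). Compound 3 `CC(C)(C)NCc1c(C(=O)O)nn(-c2ccc(Cl)cc2)c1-c1ccc(Br)cc1` carries a different core from compound 1, the difference being (chloro in place of hydrogen on an aromatic carbon). In this assay compound 3 likewise returns only a limit of the assay, > 542000 nM. The step of an at least 4.3-fold higher number from compound 1 to compound 3 (0.63 log units; beyond the scatter) rests on (the limit of > 542000 nM in this assay, at which 1 of the 3 values shown sits). Compound 4 `CC(C)(C)NCc1c(C(=O)O)nn(-c2ccc(Cl)cc2)c1-c1ccccc1` has not yet been measured; it differs from compound 3 by hydrogen in place of bromo on an aromatic carbon, and since the place reads the same word for word as for the pair of compound 1 and compound 2, this is the same change, made twice in the set. On the core of compound 1 that change produced an at least 5.6-fold higher number from compound 1 to compound 2 (0.75 log units; beyond the scatter). Starting from a value that is already a limit, the expected outcome is a step that the limit leaves unreadable from compound 3 to compound 4, most likely reported as a limit once more. Compound 4 is accordingly estimated at 1000000 nM, within a range from 500000 nM to 3000000 nM.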

Compound 4, concentration for 50% growth inhibition: > 652000 nM
Compound 4 gave a limit, no number; the forecaster's own chance of this, stated with the estimate: 85%; the middle value does not contradict the limit.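

In this assay compound 4 returns only a limit of the assay, > 652000 nM. Compound 3 is also a limit, > 542000 nM, and compound 2 is a limit too, > 716000 nM, so neither step to compound 4 can be read. The compounds shown leave open how large the change from 4-bromophenyl to phenyl is when the chloro group is present.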